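Moving the Methoxy Group Around the Benzyl Side Chain

The compounds below may be only part of what the source reports. "The series", "measured", "known", "first", "only" and "open" are said of these compounds alone.

In a functional assay on P388 cells (Mus musculus) for cytotoxicity (a higher number here means a weaker inhibitor, a lower number a stronger inhibitor), compound 1 `Cc1cc(-c2c(F)cc3c(=O)ccn(C4CC4)c3c2F)cc(C)n1` gives 15000 nM, compound 2 `COc1cccc(Cc2cn(C3CC3)c3c(F)c(-c4cc(C)nc(C)c4)c(F)cc3c2=O)c1` gives 20000 nM, and compound 3 `COc1ccc(Cc2cn(C3CC3)c3c(F)c(-c4cc(C)nc(C)c4)c(F)cc3c2=O)cc1` gives 21000 nM. Compound 3 therefore lies within the scatter of both other compounds. Compound 4 `COc1ccccc1Cc1cn(C2CC2)c2c(F)c(-c3cc(C)nc(C)c3)c(F)cc2c1=O` differs from compound 3 by 2-methoxyphenyl in place of 4-methoxyphenyl on a saturated chain carbon bound to an aromatic carbon, with 2-methoxyphenyl in place of 4-methoxyphenyl on a saturated chain carbon bound to an aromatic carbon. The closest measured precedent is a 1.1-fold higher number from compound 2 to compound 3 (0.02 log units; within the scatter), a swap of methoxyphenyl groups at the same place. The benzyl additions, a 1.3-fold higher number from compound 1 to compound 2 (0.12 log units; within the scatter) and a 1.4-fold higher number from compound 1 to compound 3 (0.15 log units; within the scatter), also stay within the scatter. No step beyond the scatter is thus expected in this assay. The estimated step is a 1.1-fold lower number from compound 3 to compound 4 (0.02 log units; within the scatter). Compound 4 is expected at 20000 nM, within an estimated range of 11000 nM to 35000 nM.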

Compound 4, half-maximal inhibitory concentration: 37000 nM
Beside the measured number, compound 4's estimate is 1.9-fold (0.27 log units) below it; measured number outside the range, above it.
By their numbers in this assay, from the lowest: compounds 1, 2, 3 and 4 (each within the scatter of the next, the first and the last beyond it).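

In this assay the 2-methoxybenzyl group stays level with its isomers, since a 1.8-fold higher number from compound 3 to compound 4 (0.25 log units; within the scatter) and a 1.9-fold higher number from compound 2 to compound 4 (0.27 log units; within the scatter) both lie within the scatter, so the position of the methoxy group on the benzyl ring is not resolved here. Set against the hydrogen, however, this group gives the first step at this place that leaves the scatter, a modest one with a 2.5-fold higher number from compound 1 to compound 4 (0.39 log units; beyond the scatter) as its size. Going by these compounds, whether a benzyl group carrying an amine or a carboxylic acid, or a longer chain at this place, would shift the number remains open. Nothing measured here accounts for these numbers.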